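The compounds below may be only part of what the source reports. "The series", "measured", "known", "first", "only" and "open" are said of these compounds alone.

Among the compounds with values here, in a functional assay on MCF7 cells (Homo sapiens) for antiproliferative activity, read by MTT assay, with a stated time of 72 h (a higher number here means a weaker inhibitor, a lower number a stronger inhibitor), compound 2 `CC1=CC[C@H]2[C@H](CC[C@]2(C)O)C(C)(C)[C@@H]1CC[C@H]1[C@]2(C)CC[C@H](OC(=O)c3ccccc3)C(C)(C)O[C@H]2CC[C@@]1(C)O` gives 21000 nM, the only measurement in this set that is a number rather than a limit of the assay. Compound 1 `CC1=CC[C@H]2[C@@H]1CC=C(C)[C@@H](CC[C@H]1[C@]3(C)CC[C@H](O)C(C)(C)O[C@H]3CC[C@@]1(C)O)C2(C)C` sits at the limit, with > 50000 nM. Compound 3 `CC1=CC[C@H]2[C@H](CC[C@]2(C)O)C(C)(C)[C@@H]1CC[C@H]1[C@]2(C)CC/C(=N/OCc3ccccc3)C(C)(C)O[C@H]2CC[C@@]1(C)O` likewise sits at the limit, with > 50000 nM. Two of the three values therefore rest at the limit of > 50000 nM in this assay, at which 2 of the 3 values shown sit, and compound 2 alone provides a measured number from which to start. Compound 4 `CC1=CC[C@H]2[C@H](CC[C@]2(C)O)C(C)(C)[C@@H]1CC[C@H]1[C@]2(C)CC[C@H](OC(=O)c3ccccc3Cl)C(C)(C)O[C@H]2CC[C@@]1(C)O` differs from compound 2 by chloro in place of hydrogen on an aromatic carbon. Within the data shown here, no step between measured compounds is available, so no size for a change of this kind has been measured here. The change is expected to move this assay by no more than the usual scatter, in either direction. Compound 4 is expected to give 18000 nM, with a range from 7000 nM to 45000 nM. The expected step of a 1.2-fold lower number from compound 2 to compound 4 (0.07 log units; within the scatter) thus stays within the scatter.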

Compound 4, half-maximal inhibitory concentration: 12100 nM
Beside the measured number, compound 4's estimate is 1.5-fold (0.17 log units) above it; low and high end bracket the measured number.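

In this assay, the change now has a measured size, a 1.7-fold lower number from compound 2 to compound 4 (0.24 log units; within the scatter), so the added chloro, ortho to a large group, leaves the number within the scatter. Compound 4 also gives a measured number rather than a limit, so the set now holds a second number beside its limits: the limit of > 50000 nM in this assay, at which 2 of the 4 values shown sit.

Going by these compounds, whether an amine, a methoxy group or a carboxylic acid at this position would move the number beyond the scatter stays open. So does whether chloro elsewhere on this ring would behave the same way.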